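The source may hold more compounds than are shown below. What is called first, only, known or untested is meant among the compounds shown, and "the series" means these compounds.

Among the measured compounds shown here, compound 3 `CCN(CC)c1ccc(N2C(=O)NC3(CSC4=C3C(=O)c3ncccc3C4=O)C2=O)cc1` gives the highest number of the three measured so far in a functional assay on HeLa cells (Homo sapiens) for antiproliferative activity, read by MTT assay, with a stated time of 96 h; a lower number here means a stronger inhibitor, a higher number a weaker inhibitor: compound 3 shows 50 nM, while compound 1 `CCCc1ccc(N2C(=O)NC3(CSC4=C3C(=O)c3ncccc3C4=O)C2=O)cc1` shows 5 nM and compound 2 `COc1ccc(N2C(=O)NC3(CSC4=C3C(=O)c3ncccc3C4=O)C2=O)cc1` shows 1 nM. The untested compound 4 `CCCCc1ccc(N2C(=O)NC3(CSC4=C3C(=O)c3ncccc3C4=O)C2=O)cc1` differs from compound 3 in one place: butyl in place of diethylamino on an aromatic carbon. The step that bears most directly on it runs the other way, a 10-fold higher number from compound 1 to compound 3 (1.00 log units; beyond the scatter); taken in reverse it suggests that replacing diethylamino with a plain alkyl chain brings the number down again. The step of a 5.0-fold lower number from compound 1 to compound 2 (0.70 log units; beyond the scatter) concerns a different group and speaks less to this change, and a 50-fold higher number from compound 2 to compound 3 (1.70 log units; beyond the scatter) shows only that diethylamino sits at the weak end. Butyl is one carbon longer than propyl, so compound 4 is expected to land near compound 1 rather than exactly on it. Compound 4 is therefore estimated at 6 nM in this assay, with a range from 2 nM to 20 nM, which amounts to an expected step of an 8.3-fold lower number from compound 3 to compound 4 (0.92 log units; beyond the scatter).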

Compound 4, half-maximal inhibitory concentration: 90 nM
Estimate against measurement, compound 4: 15-fold (1.18 log units) below, outside the stated range (above it).
By their numbers in this assay, from the lowest: compound 2; then compound 1; then compounds 3 and 4 (each within the scatter of the next).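

In this assay butyl in place of diethylamino gives a 1.8-fold higher number from compound 3 to compound 4 (0.26 log units; within the scatter) and so leaves the two groups indistinguishable on this aromatic carbon, although only diethylamino holds a nitrogen. The alkyl chains are not interchangeable here: methyl in place of hydrogen, three bonds along the chain from an aromatic carbon, gives an 18-fold higher number from compound 1 to compound 4 (1.26 log units; beyond the scatter) and butyl in place of methoxy gives a 90-fold higher number from compound 2 to compound 4 (1.95 log units; beyond the scatter) so that this position responds sharply to a small extension of the chain. No measurement at hand explains these steps. The compounds shown leave open whether ethyl or pentyl would follow the same trend as propyl and butyl. They also leave open how ethoxy, dimethylamino or a carboxylic acid would compare on this carbon.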